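Aryl exchange at the ring nitrogen of compound 2

The source may hold more compounds than are shown below. What is called first, only, known or untested is meant among the compounds shown, and "the series" means these compounds.

Measured so far in a functional assay for antagonist activity at transient receptor potential cation channel subfamily V member 1 (Rattus norvegicus), read by FLIPR; a lower number here means a less potent compound, a higher number a more potent compound, by a factor of ten per unit of this negative logarithm:
compound 1 `N#Cc1ccc(N2CC[C@@H](NC(=O)Nc3ccccc3Br)C2)nc1` gives 6.7
compound 2 `O=C(Nc1ccccc1Br)N[C@@H]1CCN(c2ccc(Br)cn2)C1` gives 7.2

Compound 2 stands highest of the two numbers in this assay; its nearest neighbour is compound 1, and the step of a number 0.50 log units higher from compound 1 to compound 2 (beyond the scatter) is beyond the scatter, a modest gain for bromo in place of cyano on an aromatic carbon.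

Compound 3 `Cc1ccc(N2CC[C@@H](NC(=O)Nc3ccccc3Br)C2)cc1F` is not yet measured. It differs from compound 2 by 3-fluoro-4-methylphenyl in place of 5-bromopyridin-2-yl on an amine nitrogen in a ring. Among the compounds with values here, no measured step touches this kind of exchange: the only step available, that from compound 1 to compound 2, alters a substituent on the same aromatic ring and leaves the ring itself in place, so it shows that this part of the molecule can shift the number by a modest amount but says nothing about the direction once the whole ring is swapped. With nothing pointing either way, the step of a number 0.10 log units lower from compound 2 to compound 3 (within the scatter) is estimated to stay within the scatter. Compound 3 is therefore expected to give about 7.1 in this assay, with a range from 6.4 to 7.8.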

Compound 3, negative logarithm of the antagonist equilibrium constant: 8.3
Compound 3: middle estimate off by 1.20 log units, on the low side, and the stated range ends below it.
By their numbers in this assay, from the lowest: compound 1; then compound 2; then compound 3.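

In this assay, replacing the whole aryl group on the amine nitrogen in a ring moves the number much further than changing a substituent on the pyridine did: the exchange gives a number 1.10 log units higher from compound 2 to compound 3 (beyond the scatter) and a number 1.60 log units higher from compound 1 to compound 3 (beyond the scatter), whereas bromo in place of cyano gives only a number 0.50 log units higher from compound 1 to compound 2 (beyond the scatter). This position therefore tolerates a six-membered aromatic ring of carbon only, and 3-fluoro-4-methylphenyl stands clear of both the 5-bromopyridin-2-yl and the 5-cyanopyridin-2-yl groups, so the identity of the ring and its substituents as a whole matters more here than the bromo and cyano exchange alone indicated. No available evidence explains the size of this gain.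

The exchange changes the ring atoms and the substituents together, so the compounds shown cannot assign the gain to the loss of the ring nitrogen, to the fluoro group or to the methyl group. Going by these compounds, whether a plain phenyl, a 4-methylphenyl or a 3-fluorophenyl on the same nitrogen would hold the number of compound 3 remains open, as does the effect of a larger group such as trifluoromethyl in place of the methyl.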